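A Fluorine for a Methyl at the Aromatic Nitrogen

This account rests on a few compounds, and the source may have more. Where it says the series, first, only, none or still open, it means among the compounds named here.

Compound 2 `Cc1cccc(-n2cc(-c3cccc(NS(=O)(=O)c4c[nH]c(=O)[nH]c4=O)c3)nn2)c1` was tested in a functional assay on HepG2 cells (Homo sapiens) for antiproliferative activity, read by MTT assay, with a stated time of 24 h (on this read-out lower numbers stand for stronger inhibition and higher numbers for weaker inhibition), where compound 2 gives 7050 nM. Among the compounds with values here, that is the only outright number recorded in this assay; the one other entry is a limit. Compound 1 `O=c1[nH]cc(S(=O)(=O)Nc2ccccc2-c2cn(-c3cccc(F)c3)nn2)c(=O)[nH]1` stands at > 20000 nM in this assay, which is a limit of the assay (the limit of > 20000 nM in this assay, at which 1 of the 2 values shown sits). Compound 3 `O=c1[nH]cc(S(=O)(=O)Nc2cccc(-c3cn(-c4ccc(F)cc4)nn3)c2)c(=O)[nH]1` has not yet been measured. It differs from compound 2 in a single place: 4-fluorophenyl in place of 3-methylphenyl on an aromatic nitrogen. Within the data shown here, no measured pair shows the effect of such a change, so no recorded step can guide the expectation. The expected shift in this assay is small, likely within the usual scatter, with a modest lean toward weaker inhibition. For compound 3 the estimated value in this assay is 9000 nM, within a range from 3000 nM to 30000 nM. That estimate implies an expected step of a 1.3-fold higher number from compound 2 to compound 3 (0.11 log units; within the scatter).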

Compound 3, half-maximal inhibitory concentration: > 20000 nM
Compound 3 gave a limit, no number (the forecaster's own chance of this, stated with the estimate: 35%); middle value at least 2.2-fold (0.34 log units) away from the limit.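

Within the data shown here, this is the first measured step at this position, and it shows that the group on the aromatic nitrogen matters: 4-fluorophenyl in place of 3-methylphenyl gives an at least 2.8-fold higher number from compound 2 to compound 3 (0.45 log units; beyond the scatter) in this assay. So a swap that leaves the heavy-atom count unchanged and keeps a single six-membered aromatic ring is still enough to weaken inhibition beyond the scatter. Because compound 3 reads only as a limit of the assay and not as a number, the true size of this step cannot be told, and the limit now holds most of the values: the limit of > 20000 nM in this assay, at which 2 of the 3 values shown sit.

The compounds shown leave open whether the loss follows the change from methyl to fluorine or the change from a 3-substituted to a 4-substituted phenyl. A 4-methylphenyl or 3-fluorophenyl group on this same core would separate the two, and an unsubstituted phenyl or a 3-aminophenyl group would show how far this position tolerates other groups.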